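The source may hold more compounds than are shown below. What is called first, only, known or untested is meant among the compounds shown, and "the series" means these compounds.

In a functional assay on HT-29 cells (Homo sapiens) for antiproliferative activity, read by MTT assay, with a stated time of 96 h (a higher number here means a weaker inhibitor, a lower number a stronger inhibitor), compound 1 `O=C1C2=C(C(=O)c3ncccc31)C1(CS2)NC(=O)N(c2ccccc2)C1=O` gives 2 nM, and compound 3 `O=C1NC(=O)C2(CSC3=C2C(=O)c2ncccc2C3=O)N1` gives 190 nM; 180 nM; 190 nM (3 entries). Compound 2 `CCCCCc1ccc(N2C(=O)NC3(CSC4=C3C(=O)c3ncccc3C4=O)C2=O)cc1`, at 250 nM, has the higher of the two single numbers, well apart from compound 1. Compound 4 `Cc1ccc(N2C(=O)NC3(CSC4=C3C(=O)c3ncccc3C4=O)C2=O)cc1` has not yet been measured. It differs from compound 2 by hydrogen in place of butyl on a saturated chain carbon bound to an aromatic carbon, which is hydrogen in place of butyl on a saturated chain carbon bound to an aromatic carbon, shortening pentyl to methyl. Within the data shown here, one measured step bears on this, the large 130-fold higher number from compound 1 to compound 2 (2.10 log units; beyond the scatter), which placed pentyl where hydrogen stood on an aromatic carbon, so the shorter chain is expected to recover much, though perhaps not all, of that rise. The expected step is a 17-fold lower number from compound 2 to compound 4 (1.22 log units; beyond the scatter), towards a lower number. For compound 4 the estimate is 15 nM, with an expected range from 3 nM to 80 nM.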

Compound 4, half-maximal inhibitory concentration: 1 nM
Compound 4: middle estimate off by 15-fold (1.18 log units), on the high side; the whole stated range lies above it.
By their numbers in this assay, from the lowest: compounds 4 and 1 (each within the scatter of the next); then compound 2.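

Read in this assay, methyl and hydrogen on an aromatic carbon cannot be told apart, with a 2.0-fold lower number from compound 1 to compound 4 (0.30 log units; within the scatter) in the numbers. The large rise with pentyl therefore does not come with any group at this place, since shortening pentyl to methyl gives a 250-fold lower number from compound 2 to compound 4 (2.40 log units; beyond the scatter) and only the longer chain stands apart. Nothing given here accounts for this dependence on chain length. Still open, going by these compounds, is where between methyl and pentyl the number turns, with ethyl, propyl or butyl, and whether methoxy or chlorine on this aromatic carbon would match methyl.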